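Second chloro on compound 3: cytotoxicity outlook

The compounds below may be only part of what the source reports. "The series", "measured", "known", "first", "only" and "open" are said of these compounds alone.

The series comprises compound 1 `ClCc1ccc(Cn2cnc3c(Cl)ncnc32)cc1`, compound 2 `ClCc1ccccc1Cn1cnc2c(Cl)ncnc21` and compound 3 `ClCc1ccccc1Cn1cnc2ncnc(Cl)c21`, all tested in a functional assay on SK-MEL-2 cells (Homo sapiens) for cytotoxicity, read by sulforhodamine B assay, with a stated time of 48 h; a lower number here means that less compound is tolerated, a higher number that more compound is tolerated. In this assay compound 1 gives > 100000 nM, a limit of the assay and not a number. Compound 2 likewise reaches only the limit, > 100000 nM. Compound 3 also sits at the limit, > 100000 nM. Among the measured compounds shown here, compound 3 thus stands where the other two stand; the whole record is the limit of > 100000 nM in this assay, at which 3 of the 3 values shown sit, and no step between measured compounds can be computed. The next compound, compound 4 `ClCc1ccccc1Cn1cnc2nc(Cl)nc(Cl)c21`, differs from compound 3 by chloro in place of hydrogen on an aromatic carbon between two ring nitrogen atoms. For the measured compounds named here, with no measured step to lean on, the expectation for compound 4 in this assay is no step beyond the scatter, the value most likely again reported only as a limit. Compound 4 is therefore estimated at 100000 nM with a range of 30000 nM to 300000 nM, which means an expected step of a number no higher from compound 3 to compound 4 (the limit leaves the size open).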

Compound 4, concentration lethal to 50% of the cells: > 100000 nM
Compound 4 was reported as a limit; the forecaster's own chance of this, stated with the estimate: 80%; the middle value sits exactly at the limit.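

In this assay no step can be read between compound 3 and compound 4, as both are reported only as limits: the limit of > 100000 nM in this assay, at which 4 of the 4 values shown sit.

The compounds shown leave open where any of them lies relative to that limit, and whether the added chloro changes cytotoxicity at all.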